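Replacing the Acid End of a Long Chain

The source may hold more compounds than are shown below. What is called first, only, known or untested is meant among the compounds shown, and "the series" means these compounds.

Of the compounds shown here, three have so far been tested in a functional assay for inhibition, with Homo sapiens as the target; a higher number here means a weaker inhibitor, a lower number a stronger inhibitor. Compound 1 `O=C(O)CCCCCCCn1nc(-c2ccccc2)c(-c2ccccc2)c1-c1ccccc1` gives 3400 nM. Compound 2 `O=C(O)CCCCCCCCCCn1nc(-c2ccccc2)c(-c2ccccc2)c1-c1ccccc1` gives 18600 nM, the higher of the two actual numbers, which makes it the weaker inhibitor of this pair. Compound 3 `O=C(O)CCCCCCCCn1nc(-c2ccccc2)cc1-c1ccccc1` reaches only a limit of the assay, > 66000 nM.

The next compound to be tested is compound 4 `NC(=O)CCCCCCCCn1nc(-c2ccccc2)c(-c2ccccc2)c1-c1ccccc1`, which keeps the core of compound 2 but has a different chain end: carbamoyl in place of 2-carboxyethyl on a saturated chain carbon, eight bonds along the chain from an aromatic nitrogen. In words, carbamoyl takes the place of 2-carboxyethyl on a saturated chain carbon, eight bonds along the chain from an aromatic nitrogen.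

Within the data shown here, only one measured step offers guidance, a change in chain length with a 5.5-fold higher number from compound 1 to compound 2 (0.74 log units; beyond the scatter). Taken alone, that step suggests that the shorter chain of compound 4 could bring a lower number than compound 2 shows. However, no measured step replaces a carboxy end with carbamoyl, so that part of the change could push the number either way, perhaps cancelling any gain. No shift beyond the usual scatter is therefore expected in this assay, and the expected step is a 1.3-fold higher number from compound 2 to compound 4 (0.13 log units; within the scatter). For compound 4, the estimated value is 25000 nM, with an expected range of 5000 nM to 100000 nM.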

Compound 4, half-maximal inhibitory concentration: 33000 nM
Estimate against measurement, compound 4: 1.3-fold (0.12 log units) below; the measured number falls inside the stated range.
By their numbers in this assay, from the lowest: compound 1; then compounds 2 and 4 (each within the scatter of the next). At a limit, above all of these: compound 3.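

In this assay, carbamoyl in place of 2-carboxyethyl gives a 1.8-fold higher number from compound 2 to compound 4 (0.25 log units; within the scatter), so at this position the loss of the carboxy end, together with a shortening of the chain, brings no shift beyond the scatter. Carbamoylmethyl in place of carboxy gives a clearer result, a 9.7-fold higher number from compound 1 to compound 4 (0.99 log units; beyond the scatter), yet a carboxy end alone does not settle the number: compound 1 and compound 2 both carry one, and only compound 1 stands apart from the amide by more than the scatter. None of the measurements shown explains these steps.

In compound 4 the end group and the chain length change together, so a carboxylic acid on the same chain and the same core would be needed to show what each change contributes. Going by these compounds, whether this position accepts other ends, such as an amine, a hydroxyl or a methyl ester, and whether a carbamoyl end on a longer chain behaves as compound 4 does, also remains open.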